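A few compounds are considered here, and "the series" means these few. Any claim that something is new, unique, unknown or untested is made for them only; others in the source may bear on it.

Measured compounds:
Compound 1 `CCOC(=O)C1CCN(C(=O)CN2CN(c3ccccc3)C3(CCN(C(=O)c4ccc(C5CCCCC5)cc4)CC3)C2=O)CC1` gives 900 nM in an assay on HEK293 cells for displacement of a labelled ligand from NPC1-like intracellular cholesterol transporter 1 (Homo sapiens); a lower number here means a stronger inhibitor, a higher number a weaker inhibitor.
Compound 2 `CC(C)(C)c1ccc(C(=O)N2CCC3(CC2)C(=O)N(CC(=O)NCCC(=O)O)CN3c2ccccc2)cc1` gives 11400 nM in this assay.

Of the two numbers in hand, compound 1 has the lower one; the gap between compound 1 and compound 2 lies beyond the usual scatter, and the two compounds differ in more than one place, so nothing can be said about any single change between them.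

Compound 3 `CC1CCCN(C(=O)CN2CN(c3ccccc3)C3(CCN(C(=O)c4ccc(C5CCCCC5)cc4)CC3)C2=O)C1` keeps the core of compound 1 and differs from it in one place: 3-methylpiperidin-1-yl in place of 4-(ethoxycarbonyl)piperidin-1-yl on a carbonyl carbon. The group that leaves carries two hydrogen-bond acceptors and a double bond outside aromatic rings; the group that enters carries none. Within the data shown here, no measured pair in this set shows what such a change does in this assay, so the direction of the step is open. Compound 3 is therefore expected to stay close to compound 1, with a step of no change at the digits printed from compound 1 to compound 3 (within the scatter) not clearly beyond the scatter. The estimate for compound 3 in this assay is 900 nM, within a range from 300 nM to 2700 nM.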

Compound 3, half-maximal inhibitory concentration: 3600 nM
Compound 3: middle estimate off by 4.0-fold (0.60 log units), on the low side; the measured number lies above the stated range.
By their numbers in this assay, from the lowest: compound 1; then compound 3; then compound 2.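

Among these compounds, this is the first step in the set that can be read at a single place: on a carbonyl carbon whose other neighbour is a saturated chain carbon, 3-methylpiperidin-1-yl in place of 4-(ethoxycarbonyl)piperidin-1-yl gives, in this assay, a 4.0-fold higher number from compound 1 to compound 3 (0.60 log units; beyond the scatter). The place is therefore not indifferent to the group it carries, and the lower number goes with the larger group, the one holding the hydrogen-bond acceptors and the double bond outside aromatic rings. The step exchanges the whole group at once, and nothing measured here accounts for it.

Open, as far as these compounds go, is which part of the exchange carries the step: the loss of the ethoxycarbonyl group, the presence of the methyl group, or where on the piperidine ring the substituent stands. From the compounds shown here alone, an unsubstituted piperidine, a piperidine bearing a carboxylic acid, or a morpholine on the same carbonyl carbon would begin to separate these, and whether the step holds with another group on the benzoyl part of the molecule also remains unknown.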